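The source may report more compounds than this note shows. Statements on the series, on what has been measured and on what is new or still open speak of the compounds shown alone.

In a functional assay on U-87MG ATCC cells (Homo sapiens) for cytotoxicity, read by MTT assay, with a stated time of 48 h (on this read-out lower numbers stand for stronger inhibition and higher numbers for weaker inhibition), so far, compound 1 (`C/C(=N\NC(=S)Nc1ccccc1Cl)c1ccccn1`) reads 2.6 nM and compound 2 (`C/C(=N/NC(=S)Nc1ccccc1I)c1ccccn1`) reads 6.1 nM as the higher of the two numbers, a gap beyond the scatter. Compound 3 (`C/C(=N/NC(=S)Nc1ccccc1Cl)c1ccccn1`) has not been measured. It differs from compound 2 by chloro in place of iodo on an aromatic carbon with chloro in place of iodo on an aromatic carbon, ortho to a large group. Among the compounds with values here, no measured step covers this swap, so the expectation rests on only two numbers and stays loose. A modest move to a lower number is expected in this assay with compound 1 at 2.6 nM as the nearest guide on the low side. The estimated move is a 1.7-fold lower number from compound 2 to compound 3 (0.24 log units; within the scatter) and may well stay within the scatter. Compound 3 is estimated at 3.5 nM with an expected range from 1.2 nM to 10 nM as the working figure.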

Compound 3, half-maximal inhibitory concentration: 2.6 nM
Estimate against measurement, compound 3: 1.3-fold (0.13 log units) above, and the stated range covers the measured number.
By their numbers in this assay, from the lowest: compounds 1 and 3 (each within the scatter of the next); then compound 2.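

With the configuration of the double bond held as drawn, chloro in place of iodo on an aromatic carbon, ortho to a large group, moves the number in this assay (a 2.3-fold lower number from compound 2 to compound 3 (0.37 log units; beyond the scatter)), so this position responds to the swap of these two groups on its own. The earlier pair, compound 1 and compound 2, differed in two places, so its gap could not be assigned to either. The configuration can now be read alone, and in this chloro pair it shows no difference (no change at the digits printed from compound 1 to compound 3 (within the scatter)), a reading that rests on one clean comparison: the fact that compounds 1 and 3 differ only in the configuration as drawn.

Going by these compounds, whether configuration stays equally silent with iodo at this position remains open. So does how this position reads with a group such as an amine or a methoxy group.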